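Adding one carbon to the selenium group of compound 3

The source may report more compounds than this note shows. Statements on the series, on what has been measured and on what is new or still open speak of the compounds shown alone.

In a functional assay on LoVo cells (Homo sapiens) for inhibition, read by MTT assay, with a stated time of 48 h (on this read-out lower numbers stand for stronger inhibition and higher numbers for weaker inhibition), compound 3 (`COc1ccc(N(C)c2nc(C)nc3ccccc23)cc1[Se]C#N`) gives 73 nM and stands second highest of three numbers. Compound 1 (`COc1ccc(N(C)c2nc(C)nc3ccccc23)cc1[Se]C`) gives 3 nM on the same read-out, while compound 2 (`COc1ccc(N(C)c2nc(C)nc3ccccc23)cc1OCCCC[Se]C#N`) gives 882 nM there. Compound 4 (`COc1ccc(N(C)c2nc(C)nc3ccccc23)cc1C[Se]C#N`) remains unmeasured and differs through a group of 4 heavy atoms (2 carbon, 1 nitrogen, 1 selenium; no ring) in place of a group of 3 heavy atoms (1 carbon, 1 nitrogen, 1 selenium; no ring), on an aromatic carbon on an aromatic carbon. The closest evidence is a 12-fold lower number from compound 2 to compound 3 (1.08 log units; beyond the scatter) as the larger group gives way to the smaller one. The other relevant step is a 24-fold higher number from compound 1 to compound 3 (1.39 log units; beyond the scatter) with cyano in place of methyl on a selenium. Neither step isolates a single added carbon, so only a small upward move is expected, estimated as a 1.6-fold higher number from compound 3 to compound 4 (0.22 log units; within the scatter) in this assay. For compound 4 the estimate is 120 nM within an expected range of 30 nM to 480 nM in this assay overall.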

Compound 4, half-maximal inhibitory concentration: 277 nM
Beside the measured number, compound 4's estimate is 2.3-fold (0.36 log units) below it; low and high end bracket the measured number.
By their numbers in this assay, from the lowest: compound 1; then compound 3; then compound 4; then compound 2.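

In this assay, one added carbon at this position, ortho to a methoxy group, is enough to carry the number beyond the scatter (a 3.8-fold higher number from compound 3 to compound 4 (0.58 log units; beyond the scatter)), while the much larger group still reads higher (a 3.2-fold lower number from compound 2 to compound 4 (0.50 log units; beyond the scatter)) and the small group of compound 1 remains far lower (a 92-fold higher number from compound 1 to compound 4 (1.97 log units; beyond the scatter)). Across these four compounds, the number rises with the heavy-atom count of this group, and none goes against that order. Nothing given here explains this rise.

On these data alone, it remains open whether this order would hold for a butyl chain on the selenium. An amine or a carboxylic acid at the end of such a chain is also untested among the compounds shown.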